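Butyl for fluoro on the aryl ketone acid series

A few compounds are considered here, and "the series" means these few. Any claim that something is new, unique, unknown or untested is made for them only; others in the source may bear on it.

For the measured compounds named here, the two measured members share one core, an aroyl acrylic acid bearing a single substituent on the aromatic ring. Compound 1 `O=C(O)/C=C/C(=O)c1ccc(Cl)cc1` carries chloro, and in a functional assay on LS174T cells (Homo sapiens) for inhibition, read by MTT assay, with a stated time of 72 h (on this read-out lower numbers stand for stronger inhibition and higher numbers for weaker inhibition), compound 1 gives 28700 nM. Compound 2 `O=C(O)/C=C/C(=O)c1ccc(F)cc1` carries fluoro instead, and in this assay compound 2 gives 33800 nM. The step of a 1.2-fold higher number from compound 1 to compound 2 (0.07 log units; within the scatter) is within the scatter, so the two compounds cannot be ordered; compound 2 simply holds the higher of the two numbers, nearest to compound 1.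

Compound 3 `CCCCc1ccc(C(=O)/C=C/C(=O)O)cc1` is the next member. The change from compound 2 is butyl in place of fluoro on an aromatic carbon. Going by the values given here, no measured step exchanges a halogen for an alkyl chain; the only step in hand, a 1.2-fold higher number from compound 1 to compound 2 (0.07 log units; within the scatter), swaps one halogen for another and stayed within the scatter. It gives no direction for a butyl replacement, and the series offers nothing else. The estimate therefore sits close to the measured pair, with a wide range in this assay. Compound 3 is expected to give 25000 nM, between 7000 nM and 80000 nM. The expected step is a 1.4-fold lower number from compound 2 to compound 3 (0.13 log units; within the scatter), not beyond the scatter.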

Compound 3, half-maximal inhibitory concentration: 6740 nM
For compound 3 the middle estimate is 3.7-fold (0.57 log units) above the measured one; the measured number lies below the stated range.
By their numbers in this assay, from the lowest: compound 3; then compounds 1 and 2 (each within the scatter of the next).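

The halogen exchange gave no readable change, but butyl on this aromatic carbon moves the number in this assay beyond the scatter, with a 5.0-fold lower number from compound 2 to compound 3 (0.70 log units; beyond the scatter) and a 4.3-fold lower number from compound 1 to compound 3 (0.63 log units; beyond the scatter). The position is therefore not indifferent to what it carries, and the steps from fluoro and from chloro agree in direction and are both modest. Nothing in hand bears on why butyl gives the lower number.

From the compounds shown here alone, with a single alkyl chain in the set, it stays open whether the lower number follows chain length; a methyl or a hexyl group on this carbon would show whether butyl is one point on a trend or an isolated case. Going by these compounds, it also stays open whether a group of another kind here, such as an amine or a carboxylic acid, would keep the number near that of compound 3 or bring it back to the level of compound 1 and compound 2.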